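The compounds below may be only part of what the source reports. "The series", "measured", "known", "first", "only" and "open" are said of these compounds alone.

Measured so far in an ADME assay on microsomes from liver (Homo sapiens) for metabolic stability; on this read-out higher numbers stand for fast clearance and lower numbers for slow clearance:
compound 1, `Cc1c(Cc2ccc(-n3cccn3)cc2)cc(C(=O)N[C@H]2CCCC[C@@H]2O)c(=O)n1C`: 20 mL/min/kg
compound 2, `Cc1c(Cc2ccc(-c3cocn3)cc2)cc(C(=O)N[C@H]2CCCC[C@@H]2O)c(=O)n1C`: 17 mL/min/kg
compound 3, `Cc1cnc(C(=O)N[C@H]2CCOC[C@@H]2O)cc1Cc1ccc(-n2cccn2)cc1`: < 8 mL/min/kg

Compound 1 and compound 2 differ in one place, (1,3-oxazol-4-yl in place of 1H-pyrazol-1-yl on an aromatic carbon), and the step of a 1.2-fold lower number from compound 1 to compound 2 (0.07 log units; within the scatter) lies within the scatter of this assay. For compound 3 the value is a limit of the assay, not a number. How the core of compound 3 differs from the core of compound 1 is not broken down here. Compound 4, `Cc1cnc(C(=O)N[C@H]2CCOC[C@@H]2O)cc1Cc1ccc(-c2cocn2)cc1`, carries the same change on the core of compound 3: 1,3-oxazol-4-yl in place of 1H-pyrazol-1-yl on an aromatic carbon. Because compound 3 already sits at the limit (the limit of < 8 mL/min/kg in this assay, at which 1 of the 3 values shown sits), and because the same change gave only a 1.2-fold lower number from compound 1 to compound 2 (0.07 log units; within the scatter), compound 4 is expected to stay close to that limit. From compound 3 the expected step is a step that the limit leaves unreadable from compound 3 to compound 4. Compound 4 is estimated at 6 mL/min/kg, between 3 mL/min/kg and 11 mL/min/kg.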

Compound 4, clearance: < 8 mL/min/kg
Compound 4 was reported as a limit; the forecaster's own chance of this, stated with the estimate: 70%; the middle value is on the limit's open side.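

In this assay, for the compounds shown here, compound 3 and compound 4 are both reported only as a limit, not a number, so no step between them can be read: the limit of < 8 mL/min/kg in this assay, at which 2 of the 4 values shown sit. Going by these compounds, whether 1,3-oxazol-4-yl in place of 1H-pyrazol-1-yl changes clearance on the core of compound 3 stays open.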